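Swapping a Diamine Bicycle for a Spiro Ether

This account rests on a few compounds, and the source may have more. Where it says the series, first, only, none or still open, it means among the compounds named here.

Compound 3 `CN1CC2CN(c3cc(C(F)(F)F)ccc3CN3CCN(C(=O)OC(C(F)(F)F)C(F)(F)F)CC3)CC2C1` gives 239 nM in an assay on brain for inhibition of Monoglyceride lipase (Mus musculus), with a stated time of 30 min (on this read-out higher numbers stand for weaker inhibition and lower numbers for stronger inhibition), the highest of the three numbers shown. Compound 1 `O=C(OC(C(F)(F)F)C(F)(F)F)N1CCN(Cc2ccc(C(F)(F)F)cc2N2CCCCC2)CC1` gives 130 nM, and the gap between them is a 1.8-fold higher number from compound 1 to compound 3 (0.26 log units; within the scatter). Compound 2 `O=C(OC(C(F)(F)F)C(F)(F)F)N1CCN(Cc2ccc(C(F)(F)F)cc2N2[C@@H]3CC[C@H]2COC3)CC1` gives 48 nM; the step between them is a 5.0-fold higher number from compound 2 to compound 3 (0.70 log units; beyond the scatter). Compound 4 `O=C(OC(C(F)(F)F)C(F)(F)F)N1CCN(Cc2ccc(C(F)(F)F)cc2N2CCC3(CCOCC3)C2)CC1` carries a group of 10 heavy atoms (8 carbon, 1 nitrogen, 1 oxygen; one five-membered non-aromatic ring with 1 hetero atom, one six-membered non-aromatic ring with 1 hetero atom) in place of a group of 9 heavy atoms (7 carbon, 2 nitrogen; 2 five-membered non-aromatic rings with 1 hetero atom each), on an aromatic carbon. Among the compounds with values here, two measured steps bear on this change: a 2.7-fold lower number from compound 1 to compound 2 (0.43 log units; beyond the scatter), where a ring group containing an oxygen replaced one without, and a 5.0-fold higher number from compound 2 to compound 3 (0.70 log units; beyond the scatter), where that oxygen-containing group gave way to the two-nitrogen group now leaving. Since compound 4 again brings in a ring holding an oxygen, a step of a 3.0-fold lower number from compound 3 to compound 4 (0.48 log units; beyond the scatter) is expected, a modest move downward. Compound 4 is therefore estimated at 80 nM, with a likely range from 30 nM to 200 nM.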

Compound 4, half-maximal inhibitory concentration: 24 nM
Estimate against measurement, compound 4: 3.3-fold (0.52 log units) above, and the stated range ends above it.
By their numbers in this assay, from the lowest: compounds 4 and 2 (each within the scatter of the next); then compounds 1 and 3 (each within the scatter of the next).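

On this aromatic carbon, a second two-ring group holding an oxygen gives a 10-fold lower number from compound 3 to compound 4 (1.00 log units; beyond the scatter) and a 5.4-fold lower number from compound 1 to compound 4 (0.73 log units; beyond the scatter) so both oxygen-bearing groups shown, not just one, give lower numbers than the groups without oxygen. The two oxygen-bearing groups differ in ring layout yet cannot be told apart in this read-out, with a 2.0-fold lower number from compound 2 to compound 4 (0.30 log units; within the scatter) as the step between them. Nothing available gives a reason for these steps.

Still open, going by these compounds, is whether a plain morpholine on this carbon would match compound 4. Also open, on these data alone, is whether an all-carbon ring in place of the oxygen-bearing six-membered ring of compound 4 would keep its number.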